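This account rests on a few compounds, and the source may have more. Where it says the series, first, only, none or still open, it means among the compounds named here.

Measured compounds:
compound 1, `COc1cc(OC)c2c(=O)cc(-c3ccc(OCCCN(C)C)cc3)oc2c1`, which in a functional assay (Homo sapiens) for antiproliferative activity, read by resazurin assay, with a stated time of 48 h, tested at 20 uM (on this read-out lower numbers stand for a weaker effect and higher numbers for a stronger effect at the one concentration tested), gives 86%
compound 2, `COc1cc(OC)c2c(=O)cc(-c3ccc(OCCN4CCCC4=O)cc3)oc2c1`, which in this assay gives 33%
compound 3, `COc1cc(OC)c2c(=O)cc(-c3ccc(OCCCN)cc3)oc2c1`, for which this assay gives "not determined" (no result reported)

Compound 3 therefore has no number of its own to stand on; it is known only by its structure. Compound 4, `COc1cc(OC)c2c(=O)cc(-c3ccc(-c4ccc(F)nc4)cc3)oc2c1`, differs from it in one place: 6-fluoropyridin-3-yl in place of 3-aminopropoxy on an aromatic carbon.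

One measured step speaks to this change, though only indirectly. It is a number 53 percentage points lower from compound 1 to compound 2 (beyond the scatter): there, the basic amine at the end of the chain was exchanged for a neutral lactam, and the effect fell sharply. Compound 4 carries no chain and no basic amine at all, so the reading of compound 1 seems the less likely outcome and the reading of compound 2 the nearer guide, with added uncertainty since the whole chain is gone rather than altered. In this assay compound 4 is therefore expected to give 30%, within a range from 8% to 60%.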

Compound 4, a percentage reported as inhibition, at one concentration (the size of the read-out at that concentration, not a potency): 19%
For compound 4 the middle estimate is 11 percentage points above the measured one; measured number inside the range.
By their numbers in this assay, from the lowest: compound 4; then compound 2; then compound 1.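

In this assay the 6-fluoropyridin-3-yl group on this aromatic carbon gives a reading that falls by a number 67 percentage points lower from compound 1 to compound 4 (beyond the scatter) and so loses most of the effect seen with the 3-(dimethylamino)propoxy group. The lactam chain was already a weak replacement, yet the change still goes further down with a number 14 percentage points lower from compound 2 to compound 4 (beyond the scatter) and this step, though modest, lies beyond the scatter. Of the three compounds with numbers, only compound 1 keeps a strong effect at this position, and nothing at hand explains the differences between them.

Compound 3 has no number, so the 3-aminopropoxy chain with its primary amine remains unplaced among these readings. As far as these compounds go, it also stays open whether the fluorine or the pyridine ring matters in compound 4, which a plain phenyl or an unfluorinated pyridin-3-yl group would address.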